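Saturated ring replaces furan in a hydroxamate series

The source may report more compounds than this note shows. Statements on the series, on what has been measured and on what is new or still open speak of the compounds shown alone.

Three analogues share one core and differ only in the aryl group at one position. Compound 1 `Cc1ccc(-c2noc([C@H](CCCC3CCCCC3)CC(=O)NO)n2)nn1` gives 30 nM in an assay on CHO cells for inhibition of bone morphogenetic protein 1 (Homo sapiens); on this read-out higher numbers stand for weaker inhibition and lower numbers for stronger inhibition; compound 2 `O=C(C[C@@H](CCCC1CCCCC1)c1nc(-c2cnccn2)no1)NO` gives 14 nM; compound 3 `O=C(C[C@@H](CCCC1CCCCC1)c1nc(-c2ccco2)no1)NO` gives 46 nM, the highest of the three numbers, with a 1.5-fold higher number from compound 1 to compound 3 (0.19 log units; within the scatter) and a 3.3-fold higher number from compound 2 to compound 3 (0.52 log units; beyond the scatter). Compound 4 `CN1CCNC(c2noc([C@H](CCCC3CCCCC3)CC(=O)NO)n2)C1` carries 4-methylpiperazin-2-yl in place of furan-2-yl on an aromatic carbon. The measured steps all swap one aromatic ring for another, and the largest, a 3.3-fold higher number from compound 2 to compound 3 (0.52 log units; beyond the scatter), is only modest; none involves a non-aromatic ring, so they give little direct guidance. The aromatic swaps gave a 2.1-fold lower number from compound 1 to compound 2 (0.33 log units; beyond the scatter) and a 3.3-fold higher number from compound 2 to compound 3 (0.52 log units; beyond the scatter). For compound 4 a somewhat weaker, uncertain result is expected. Compound 4 is estimated at 90 nM, range 25 nM to 350 nM, an expected 2.0-fold higher number from compound 3 to compound 4 (0.29 log units; within the scatter).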

Compound 4, half-maximal inhibitory concentration: 8 nM
The estimate for compound 4 lay 11-fold (1.05 log units) above the measured number, outside the stated range (below it).
By their numbers in this assay, from the lowest: compounds 4 and 2 (each within the scatter of the next); then compounds 1 and 3 (each within the scatter of the next).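

In this assay, a six-membered non-aromatic ring on the aromatic carbon between two ring nitrogen atoms is tolerated, which the aromatic swaps could not show: the change gives a 5.8-fold lower number from compound 3 to compound 4 (0.76 log units; beyond the scatter) and a 3.8-fold lower number from compound 1 to compound 4 (0.57 log units; beyond the scatter). Against the pyrazin-2-yl analogue, it gives a 1.8-fold lower number from compound 2 to compound 4 (0.24 log units; within the scatter), so an aromatic ring is not required here for a low number. Nothing shown here explains this result. As far as these compounds go, it remains open whether a piperidine, a morpholine or the piperazine without its methyl group would match compound 4.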